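A few compounds are considered here, and "the series" means these few. Any claim that something is new, unique, unknown or untested is made for them only; others in the source may bear on it.

Measured so far:
compound 1 `COc1ccc(-c2cc(Nc3nnc(-c4ccc(C)cc4)s3)cs2)cc1` gives "not determined" (no result reported) in a functional assay on B16-F10 cells (Mus musculus) for inhibition, read by colorimetric assay and MTT assay, with a stated time of 72 h; on this read-out lower numbers stand for stronger inhibition and higher numbers for weaker inhibition;
compound 2 `Cc1ccc(-c2nnc(Nc3csc(-c4ccccc4)c3)s2)cc1` gives 4000 nM in this assay;
compound 3 `Cc1ccc(-c2cc(Nc3nnc(-c4ccc(C)cc4)s3)cs2)cc1` gives "not determined" (no result reported) in this assay.

Going by the values given here, compound 2 thus holds the only number in this assay; the other two entries carry no result, so nothing can be compared against it. Compound 4 `COc1ccc(-c2nnc(Nc3csc(-c4ccccc4)c3)s2)cc1` differs from compound 2 in a single spot: methoxy in place of methyl on an aromatic carbon. Among the compounds with values here, no pair of measured compounds shows what such a swap does here. Swapping one small group for another of similar size on the outer ring is expected to move the number little, if at all, in either direction, so no step beyond the usual scatter is expected. For compound 4 the estimate in this assay is 4000 nM, with a range from 1500 nM to 12000 nM, an expected step of no change at the digits printed from compound 2 to compound 4 (within the scatter) from the value of compound 2.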

Compound 4, half-maximal inhibitory concentration: 6000 nM
For compound 4 the middle estimate is 1.5-fold (0.18 log units) below the measured one; the range from low to high includes it.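

In this assay the change from 4-methylphenyl to 4-methoxyphenyl gives a 1.5-fold higher number from compound 2 to compound 4 (0.18 log units; within the scatter) and so shows no difference that stands out from repeat measurements at this position, para to a large group. Going by these compounds alone, this is the first comparison the series allows, as the other two entries carry no number. No outside evidence bears on this result.

The compounds shown leave open how this position responds to a different kind of group, such as an amine or a carboxylic acid. As far as these compounds go, a longer chain, such as butoxy, also remains untested here.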